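Removing the carbamoyl from the benzyl group of compound 2

A few compounds are considered here, and "the series" means these few. Any claim that something is new, unique, unknown or untested is made for them only; others in the source may bear on it.

Two compounds have been measured in an ADME assay on BaF3 cells (Mus musculus) for cytotoxicity; a lower number here means that less compound is needed, a higher number that more compound is needed for the effect:
Compound 1 `CCn1ncc2c(Nc3ccc(OC(F)(F)F)cc3)ncnc21` gives > 10000 nM.
Compound 2 `NC(=O)c1ccc(Cn2ncc3c(Nc4ccc(OC(F)(F)F)cc4)ncnc32)cc1` gives > 10000 nM.

The value for compound 1 is a limit of the assay. The value for compound 2 is likewise a limit, and (the limit of > 10000 nM in this assay, at which 2 of the 2 values shown sit). The step that the two limits leave unreadable from compound 1 to compound 2 is therefore unreadable. Compound 3 `FC(F)(F)Oc1ccc(Nc2ncnc3c2cnn3Cc2ccccc2)cc1` differs from compound 2 by hydrogen in place of carbamoyl on an aromatic carbon. Among the measured compounds shown here, no measured step bears readably on this change, and nothing in the measured pair points away from the limit. Compound 3 is therefore expected at 15000 nM, within 5000 nM to 40000 nM, most likely again reported as a limit. The step that the limit leaves unreadable from compound 2 to compound 3 is expected to stay within scatter.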

Compound 3, half-maximal effective concentration: > 10000 nM
Compound 3: a limit, no number; the forecaster's own chance of this, stated with the estimate: 85%; the middle value is on the limit's open side.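

In this assay, among the compounds shown here, compound 3 gives > 10000 nM, which is a limit, so no step among compound 1, compound 2 and compound 3 can be read. The compounds shown leave open where a measurable value for any of them would lie: the limit of > 10000 nM in this assay, at which 3 of the 3 values shown sit.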